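The source may hold more compounds than are shown below. What is called first, only, known or untested is meant among the compounds shown, and "the series" means these compounds.

Of the compounds shown here, three have been tested in a functional assay on HCT-116 cells (Homo sapiens) for cytotoxicity, read by sulforhodamine B assay, with a stated time of 48 h, tested at 1 uM (on this read-out lower numbers stand for a stronger effect and higher numbers for a weaker effect at the one concentration tested), and a fourth awaits its number. Compound 1 `COc1cc(C)cc(-c2c(-c3ccnc(-c4ccc(C(C)=O)cc4)c3)cnn2CC#N)c1` gives -27% in this assay. Compound 2 `Cc1cc(O)cc(-c2nn(CC#N)cc2-c2ccnc(-c3ccc(Oc4ccccc4)cc3)c2)c1` gives -100%, the lowest of the three and so the strongest effect seen here. Compound 3 `COc1cc(C)cc(-c2nn(CC#N)cc2-c2ccnc(-c3ccc(N(C)C)cc3)c2)c1` gives -41%, which places it second highest of the three numbers: its nearest neighbour is compound 1, whose number is higher by an amount beyond the usual scatter, and the furthest is compound 2, whose number is lower by a wide margin.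

The step under consideration leads from compound 3 to compound 4 `Cc1cc(O)cc(-c2nn(CC#N)cc2-c2ccnc(-c3ccc(N(C)C)cc3)c2)c1`. The two structures differ in one place only: hydrogen in place of methyl on an oxygen on an aromatic ring. Compound 2 also carries a hydroxy at the same position, yet it differs from compound 4 elsewhere in the structure as well, so no single-change comparison with it is available; only the two values themselves can be set side by side.

Going by the values given here, no measured pair shows exactly this change, so the size of the step must be estimated. Among the compounds with values here, because compound 2, the only compound with a hydroxy here, reads -100%, the expectation is a move toward a lower number, beyond the scatter, meaning a stronger effect in this assay; the expected step from compound 3 to compound 4 is a number 21 percentage points lower from compound 3 to compound 4 (beyond the scatter). Compound 4 is therefore estimated at -62%, within a range from -100% to -30%.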

Compound 4, a percentage reported as activity, at one concentration (the size of the read-out at that concentration, not a potency): 2%
For compound 4 the middle estimate is 64 percentage points below the measured one, outside the stated range (above it).
By their numbers in this assay, from the lowest: compound 2; then compound 3; then compound 1; then compound 4.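

In this assay, replacing methoxy with hydroxy on the 3-methoxy-5-methylphenyl group gives a number 43 percentage points higher from compound 3 to compound 4 (beyond the scatter) and therefore a weaker effect at the one concentration tested. This first single-change comparison shows that this position is sensitive, even to the loss of a methyl with its one carbon, and that with dimethylamino present the hydroxy does not bring the strong effect seen with compound 2. With the hydroxy held constant, dimethylamino in place of phenoxy gives a number 102 percentage points higher from compound 2 to compound 4 (beyond the scatter), so the strong effect of compound 2 cannot be credited to the hydroxy alone, and no measured evidence here explains either step.

As far as these compounds go, it remains open whether the change from methoxy to hydroxy would have the same direction and size with phenoxy in place of dimethylamino, since one pair cannot show whether the two changes act independently. Also open, from the compounds shown here alone, is how an ethoxy group or an amino group would read in place of the methoxy, which would show whether the effect follows the size of the group or the nature of the atom attached to the ring.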